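This account rests on a few compounds, and the source may have more. Where it says the series, first, only, none or still open, it means among the compounds named here.

Measured so far:
- compound 1, `CC#CCn1c(N2CCC[C@@H](N)C2)cc(=O)n(Cc2ccc(F)cc2C(=O)O)c1=O`: > 100000 nM
- compound 2, `CC#CCn1c(N2CCC[C@@H](N)C2)cc(=O)n(Cc2cccc(F)c2C(=O)O)c1=O`: > 100000 nM

Both of these values come from an ADME assay on Sf9 cells for inhibition of Dipeptidyl peptidase 9 (Homo sapiens), read by fluorescence, with stated times of 60 s and 20 min; a lower number here means a stronger inhibitor, a higher number a weaker inhibitor. For compound 1 the value > 100000 nM is a limit of the assay, not a number. For compound 2 the value > 100000 nM is likewise a limit. The step that the two limits leave unreadable from compound 1 to compound 2 therefore cannot be read, because of the limit of > 100000 nM in this assay, at which 2 of the 2 values shown sit. Compound 2 thus stands at the ceiling of what this assay reports, with no measured number of its own.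

Compound 3, `CC#CCn1c(N2CCC[C@@H](N)C2)cc(=O)n(Cc2ccc(Cl)cc2C(=O)O)c1=O`, is not yet measured. It differs from compound 2 in one place: 2-carboxy-4-chlorophenyl in place of 2-carboxy-3-fluorophenyl on a saturated chain carbon bound to an aromatic nitrogen. This returns to the same ring-substitution pattern as compound 1, with chlorine standing where compound 1 carries fluorine.

Among the compounds with values here, the only measured step that bears on this change is a step that the two limits leave unreadable from compound 1 to compound 2, which is unreadable because of the limit of > 100000 nM in this assay, at which 2 of the 2 values shown sit. With both neighbours at the limit, the step of a number no higher from compound 2 to compound 3 (the limit leaves the size open) is expected to be none beyond the scatter, and compound 3 is expected to give 100000 nM in this assay, within a range of 30000 nM to 300000 nM.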

Compound 3, half-maximal inhibitory concentration: > 100000 nM
Compound 3: only a limit was reported; the forecaster's own chance of this, stated with the estimate: 80%; the middle value sits exactly at the limit.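

In this assay compound 3 gives > 100000 nM, which is a limit and not a number. No step among compound 1, compound 2 and compound 3 can be read, because all three share that limit: the limit of > 100000 nM in this assay, at which 3 of the 3 values shown sit.

The compounds shown leave open how strongly each one inhibits, and whether chloro in place of fluoro changes anything.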